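This account rests on a few compounds, and the source may have more. Where it says the series, first, only, none or still open, it means among the compounds named here.

Measured compounds:
compound 1, `CC(C(=O)NCc1ccc(C2CC2)nc1N1CCCCC1)c1ccc(NS(C)(=O)=O)c(F)c1`: 1.1 nM
compound 2, `CC(C(=O)NCc1ccc(C(F)(F)Cl)nc1N1CCN(c2ccccc2)CC1)c1ccc(NS(C)(=O)=O)c(F)c1`: 0.8 nM

Both were tested in an assay on CHO cells for antagonist activity at transient receptor potential cation channel subfamily V member 1 (Homo sapiens), read by FLIPR; a higher number here means a weaker inhibitor, a lower number a stronger inhibitor. Compound 2 shows the lower of the two numbers, but its gap to compound 1 lies within the usual scatter, so the two count as alike. Compound 3, `CC(C(=O)NCc1ccc(C(F)(F)Cl)nc1SC1CCCCC1)c1ccc(NS(C)(=O)=O)c(F)c1`, has not been measured. It differs from compound 2 in one place: cyclohexylsulfanyl in place of 4-phenylpiperazin-1-yl on an aromatic carbon. Among the compounds with values here, no measured pair shows this change, so its effect is open. A modest rise in the number, meaning a somewhat weaker inhibitor, is expected, a 3.8-fold higher number from compound 2 to compound 3 (0.57 log units; beyond the scatter). In this assay compound 3 is estimated at 3 nM, with a range from 0.7 nM to 15 nM.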

Compound 3, inhibition constant: 3 nM
Beside the measured number, compound 3's estimate shows no gap at the digits printed; the range from low to high includes it.
By their numbers in this assay, from the lowest: compounds 2 and 1 (each within the scatter of the next); then compound 3.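

In this assay, placing cyclohexylsulfanyl instead of 4-phenylpiperazin-1-yl next to the ring nitrogen gives a 3.8-fold higher number from compound 2 to compound 3 (0.57 log units; beyond the scatter), a modest weakening that lies beyond the scatter. This position therefore accepts a sulfur-linked carbon ring without a large loss, with compound 3 at 3 nM. No available measurement bears on the reason for this step. From the compounds shown here alone, the linking atom and the ring both change in this single step, and their separate contributions remain open. Cyclohexylamino or phenylsulfanyl at this position would each change only one of them.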